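This account rests on a few compounds, and the source may have more. Where it says the series, first, only, none or still open, it means among the compounds named here.

In a functional assay on SMMC-7721 cells (Homo sapiens) for inhibition, read by CCK-8 assay, with a stated time of 72 h, tested at 8 uM (a lower number here means less inhibition of growth, a higher number more inhibition of growth at the concentration tested), compound 3 `Nc1ccccc1NC(=O)c1ccc(CSc2cccc(F)c2)cc1` gives 83%, the highest of the three numbers available and beyond the scatter from both others. Compound 1 `Cc1cc(C)cc(SCc2ccc(/C=C/C(=O)Nc3ccccc3N)cc2)c1` gives 7.13% and compound 2 `Nc1ccccc1NC(=O)/C=C/c1ccc(CSc2ccc(Cl)cc2)cc1` gives 16.5%. Compound 4 `Nc1ccccc1NC(=O)c1ccc(CSc2ccc(F)cc2)cc1` has the same atoms as compound 3, joined differently, with 4-fluorophenyl in place of 3-fluorophenyl on a sulfur. For the measured compounds named here, only one measured step changes a group on such a sulfur, a number 9.4 percentage points higher from compound 1 to compound 2 (within the scatter), and it stays within the scatter. Going by the values given here, it comes from a different core, so it is a thin guide, and no step from compound 3 itself has been measured. The expected change is small and within the scatter, a number 7 percentage points lower from compound 3 to compound 4 (within the scatter). For compound 4 the estimated value is 76%, with an expected range of 52% to 92%.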

Compound 4, percent growth inhibition at one concentration: 81.9%
Compound 4: middle estimate off by 5.9 percentage points, on the low side; measured number inside the range.
By their numbers in this assay, from the lowest: compounds 1 and 2 (each within the scatter of the next); then compounds 4 and 3 (each within the scatter of the next).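

In this assay the fluorine changes place on the ring attached to the sulfur, and the result is a number 1.1 percentage points lower from compound 3 to compound 4 (within the scatter), so the data do not separate 3-fluorophenyl from 4-fluorophenyl here. For the compounds shown here, this is the only measured change at this sulfur on the core of compound 3, and it keeps the aryl ring and its single fluorine. No measured evidence on the cause of this result is available. Still open, from the compounds shown here alone, is how this core responds to a larger change on the sulfur, such as 4-methoxyphenyl or an ethyl chain in place of the fluorophenyl ring.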